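Trifluoromethoxy for trifluoromethyl on the pendant aryl ring

This account rests on a few compounds, and the source may have more. Where it says the series, first, only, none or still open, it means among the compounds named here.

Two compounds of the series have numbers in a functional assay on NCI-H2122 cells (Homo sapiens) for inhibition, read by microscopy, with a stated time of 10 days; on this read-out higher numbers stand for weaker inhibition and lower numbers for stronger inhibition. Compound 1 `Cc1nn(C)c2c1C(c1ccccc1)C(C#N)=C(N)O2` gives 9100 nM. Compound 2 `Cc1nn(C)c2c1C(c1ccc(C(F)(F)F)cc1)C(C#N)=C(N)O2` gives 2200 nM. Among the compounds with values here, the one step measured so far, a 4.1-fold lower number from compound 1 to compound 2 (0.62 log units; beyond the scatter), brings the series to its lowest number: compound 2 stands lowest of the two, and its nearest neighbour, compound 1, sits at a higher number beyond the scatter.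

Compound 3 `Cc1nn(C)c2c1C(c1ccc(OC(F)(F)F)cc1)C(C#N)=C(N)O2` is not yet measured. It differs from compound 2 by trifluoromethoxy in place of trifluoromethyl on an aromatic carbon. Within the data shown here, no measured step covers this exchange; the only step on record, from compound 1 to compound 2, concerns the entry of trifluoromethyl where hydrogen stood and says nothing about swapping one fluorinated group for another at the same place. Both groups are without ring and without net charge, and the exchange is expected to stay within the usual scatter in this assay, with a 1.1-fold higher number from compound 2 to compound 3 (0.06 log units; within the scatter) as the expected change. Compound 3 is accordingly estimated at 2500 nM, with a range of 900 nM to 7000 nM.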

Compound 3, half-maximal inhibitory concentration: 2900 nM
For compound 3 the middle estimate is 1.2-fold (0.06 log units) below the measured one; measured number inside the range.
By their numbers in this assay, from the lowest: compounds 2 and 3 (each within the scatter of the next); then compound 1.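

In this assay, trifluoromethoxy on this aromatic carbon, para to a large group, cannot be told apart from trifluoromethyl, with a 1.3-fold higher number from compound 2 to compound 3 (0.12 log units; within the scatter). The lower number seen on replacing hydrogen at this place is therefore not confined to one fluorinated group, as trifluoromethoxy also gives a step beyond the scatter, with a 3.1-fold lower number from compound 1 to compound 3 (0.50 log units; beyond the scatter), and the added oxygen and the hydrogen-bond acceptor it brings leave compound 3 within the scatter of compound 2. No measurement at hand explains why the two groups read alike.

Going by these compounds, both groups that improve on hydrogen here are fluorinated, so it remains open whether a methyl, a methoxy, a chlorine or a carboxylic acid at this place would also give a number below that of compound 1, or whether the step belongs only to groups of the fluorinated kind. Also open, on these data alone, is whether trifluoromethyl and trifluoromethoxy would remain indistinguishable on another carbon of the same ring, or with a different group in place of the nitrile on the shared core.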